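The source may hold more compounds than are shown below. What is called first, only, known or untested is meant among the compounds shown, and "the series" means these compounds.

In a functional assay on K562 cells (Homo sapiens) for cytotoxicity, read by MTT assay, with a stated time of 5 days (on this read-out lower numbers stand for stronger inhibition and higher numbers for weaker inhibition), three compounds have been measured so far:

- compound 1 `COc1ccc(Cn2nncc2-c2cc(OC)c(OC)c(OC)c2)cc1`: 8660 nM
- compound 2 `COc1ccc(Cn2nncc2-c2cc(OC)c(OC)c(OC)c2)cc1[N+](=O)[O-]`: > 10000 nM
- compound 3 `COc1ccc(-c2cnnn2Cc2cc(OC)c(OC)c(OC)c2)cc1`: 5560 nM

Compound 2 has the entry > 10000 nM, which is a limit of the assay and not a number. It is the only one of the three entries of this kind, as the limit of > 10000 nM in this assay, at which 1 of the 3 values shown sits, records. The two true numbers, compound 3 at 5560 nM and compound 1 at 8660 nM, lie within the scatter of each other.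

Compound 4 `COc1ccc(-c2cnnn2Cc2cc(OC)c(OC)c(OC)c2)cc1[N+](=O)[O-]` has not yet been measured. It is compound 3 with nitro in place of hydrogen on an aromatic carbon, ortho to a methoxy group and meta to a large group: nitro in place of hydrogen on an aromatic carbon.

The same kind of change has been measured only once, as an at least 1.1-fold higher number from compound 1 to compound 2 (0.06 log units; that floor lies within the scatter). That step gives only a floor, so a modest rise in this assay is expected, perhaps none beyond the scatter, and the reading could also end at the limit of the assay.

For compound 4, the expected value is 7500 nM, with an estimated range of 3000 nM to 15000 nM. This corresponds to an expected step of a 1.3-fold higher number from compound 3 to compound 4 (0.13 log units; within the scatter).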

Compound 4, half-maximal inhibitory concentration: > 10000 nM
Compound 4 was reported as a limit; the forecaster's own chance of this, stated with the estimate: 35%; middle value at least 1.3-fold (0.12 log units) away from the limit.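

In this assay nitro in place of hydrogen on an aromatic carbon, ortho to a methoxy group and meta to a large group, gives an at least 1.7-fold higher number from compound 3 to compound 4 (0.25 log units; that floor lies within the scatter), so the change has now been read on a second core, that of compound 3. On both cores the reading is a floor and not a full step, and neither shows a drop in the number: the same change on two cores in this assay, an at least 1.1-fold higher number (0.06 log units; that floor lies within the scatter) from compound 1 to compound 2 and an at least 1.7-fold higher number (0.25 log units; that floor lies within the scatter) from compound 3 to compound 4; the limit leaves it open whether they differ

With compound 4, both nitro compounds shown sit at the limit, while the two compounds carrying hydrogen in that place, compound 1 and compound 3, give true numbers: the limit of > 10000 nM in this assay, at which 2 of the 4 values shown sit.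

Going by these compounds, what compound 2 and compound 4 would read as true numbers stays open, so the size of the change on either core is unknown, and so is any difference between the cores. Also open, on these data alone, is whether an amine or a carboxylic acid in the same place, ortho to a methoxy group and meta to a large group, would give a true number in this assay or would likewise end at the limit.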